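Indazolyl in Place of Difluorophenyl: Expected Cytotoxicity

This account rests on a few compounds, and the source may have more. Where it says the series, first, only, none or still open, it means among the compounds named here.

The three measured compounds and their values in an ADME assay on MT4 cells (Homo sapiens) for cytotoxicity, read by MTT assay (on this read-out higher numbers stand for lower toxicity in this test and lower numbers for higher toxicity in this test), are these. Compound 1 `Cc1cc(C)cc(S(=O)(=O)c2c(C(=O)NCc3cccc(N)c3)[nH]c3ccc(Cl)cc23)c1` gives > 53400 nM, which is a limit of the assay. Compound 2 `Cc1cc(C)cc(S(=O)(=O)c2c(C(=O)NCc3cccc(F)c3F)[nH]c3ccc(Cl)cc23)c1` gives > 51100 nM, again a limit of the assay. Compound 3 `Cc1cc(C)cc(S(=O)(=O)c2c(C(=O)NC(C)C(=O)NC(C)c3ccccc3F)[nH]c3ccc(Cl)cc23)c1` gives 15200 nM.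

Compound 2 therefore stands at a limit, and one further value sits at a limit as well, as the limit of > 53400 nM in this assay, at which 1 of the 3 values shown sits, and the limit of > 51100 nM in this assay, at which 1 of the 3 values shown sits, show; only compound 3 carries a number. Within the data shown here, the single one-place step among the measured compounds, a step that the two limits leave unreadable from compound 1 to compound 2, runs between two limits and cannot be read. Compound 3 differs from compound 2 in more than one place, so its value alone is noted.

Compound 4 `Cc1cc(C)cc(S(=O)(=O)c2c(C(=O)NCc3n[nH]c4ccccc34)[nH]c3ccc(Cl)cc23)c1` carries the change (1H-indazol-3-yl in place of 2,3-difluorophenyl on a saturated chain carbon bound to an amide-type nitrogen). No readable step bears on this change, so the expectation rests on compound 2 standing at a limit of this assay. Compound 4 is expected to show a step of about an at least 1.1-fold lower number from compound 2 to compound 4 (0.05 log units; that floor lies within the scatter), that is, no change beyond the scatter. The expected value of compound 4 is 45000 nM, within 18000 nM to 110000 nM, with a fair chance that only a limit is reported again.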

Compound 4, half-maximal cytotoxic concentration: > 50700 nM
Compound 4: no number, only a limit (the forecaster's own chance of this, stated with the estimate: 55%); at least 1.1-fold (0.05 log units) between middle value and limit.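

In this assay compound 4 gives only a limit, as do compound 1 and compound 2, and the steps from compound 1 and compound 2 to compound 4 cannot be read. The compounds shown leave open whether 1H-indazol-3-yl, 2,3-difluorophenyl and 3-aminophenyl differ at all in this assay.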